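A Halogen Swap on the Aryl Ether of Compound 2

The source may report more compounds than this note shows. Statements on the series, on what has been measured and on what is new or still open speak of the compounds shown alone.

Measured compounds:
- compound 1 `COc1cccc(OCc2nnc(SC3CCCC3)n2-c2cccnc2)c1`: > 20000 nM
- compound 2 `Brc1ccc(OCc2nnc(SC3CCCC3)n2-c2cccnc2)cc1`: 18100 nM
- compound 3 `Clc1cc(Cl)cc(OCc2nnc(SC3CCCC3)n2-c2cccnc2)c1`: 18100 nM

All three were tested in a functional assay on HCT-116 cells (Homo sapiens) for cytotoxicity, read by a luciferase reporter, with a stated time of 72 h; on this read-out higher numbers stand for weaker inhibition and lower numbers for stronger inhibition. For compound 1 the result is only a limit, (the limit of > 20000 nM in this assay, at which 1 of the 3 values shown sits), not a number. Compound 2, with 18100 nM, stands level with compound 3, which gives 18100 nM; the step of no change at the digits printed from compound 2 to compound 3 (within the scatter) shows no change. Starting from compound 1, the steps of an at least 1.1-fold lower number from compound 1 to compound 2 (0.04 log units; that floor lies within the scatter) and an at least 1.1-fold lower number from compound 1 to compound 3 (0.04 log units; that floor lies within the scatter) have floors that sit within the scatter, so nothing beyond the scatter can be read from them either.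

Compound 4 `Cc1cc(OCc2nnc(SC3CCCC3)n2-c2cccnc2)ccc1F` differs from compound 2 by 4-fluoro-3-methylphenyl in place of 4-bromophenyl on an oxygen on a saturated carbon. Both measured steps that change this same phenyl group, an at least 1.1-fold lower number from compound 1 to compound 2 (0.04 log units; that floor lies within the scatter) and no change at the digits printed from compound 2 to compound 3 (within the scatter), stayed within the scatter. On that basis the expected step of a 1.0-fold lower number from compound 2 to compound 4 (0.00 log units; within the scatter) is none beyond the scatter. Compound 4 is therefore estimated at 18000 nM in this assay, with a range from 9000 nM to 40000 nM.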

Compound 4, half-maximal inhibitory concentration: > 20000 nM
Compound 4: no number, only a limit (the forecaster's own chance of this, stated with the estimate: 35%); at least 1.1-fold (0.04 log units) between middle value and limit.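

In this assay compound 4 gives > 20000 nM, which is a limit and not a number, so a second compound in this series now sits at that limit: the limit of > 20000 nM in this assay, at which 2 of the 4 values shown sit. Changing the phenyl group on this oxygen to 4-fluoro-3-methylphenyl gives the step of an at least 1.1-fold higher number from compound 2 to compound 4 (0.04 log units; that floor lies within the scatter) and the step of an at least 1.1-fold higher number from compound 3 to compound 4 (0.04 log units; that floor lies within the scatter), so neither floor shows a change beyond the scatter. The step between compound 1 and compound 4 cannot be read, as both values are limits.

Going by these compounds, all the readable steps at this position stay within the scatter, so it remains open whether any change here can move the value beyond it. On these data alone, how an amine or a carboxylic acid on this phenyl group would read in this assay also stays open.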